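Fluoro for methylsulfanyl on the fused aromatic ring

This account rests on a few compounds, and the source may have more. Where it says the series, first, only, none or still open, it means among the compounds named here.

Measured compounds in an assay on CHO-K1 cells for binding affinity to muscarinic acetylcholine receptor M5 (Homo sapiens); a lower number here means a stronger inhibitor, a higher number a weaker inhibitor:
Compound 1, `Cc1ccc2c(c1)C(C(C)c1ccccn1)=C(CCN(C)C)C2`: 5890 nM
Compound 2, `CC(C1=C(CCN(C)C)Cc2ccc(Cl)cc21)c1ccccn1`: 912 nM
Compound 3, `CSc1ccc2c(c1)C(C(C)c1ccccn1)=C(CCN(C)C)C2`: 3240 nM

Compound 3 stands second highest of the three; its nearest neighbour is compound 1, within the scatter, and compound 2 lies furthest, giving a 3.6-fold higher number from compound 2 to compound 3 (0.55 log units; beyond the scatter). Compound 4, `CC(C1=C(CCN(C)C)Cc2ccc(F)cc21)c1ccccn1`, differs from compound 3 by fluoro in place of methylsulfanyl on an aromatic carbon. Among the compounds with values here, two steps bear on this change: the move from chloro to methylsulfanyl, a 3.6-fold higher number from compound 2 to compound 3 (0.55 log units; beyond the scatter), and the move from methyl to chloro, a 6.5-fold lower number from compound 1 to compound 2 (0.81 log units; beyond the scatter). Both point to a lower number for a halogen at this position, so a modest drop is expected. The expected step is a 1.6-fold lower number from compound 3 to compound 4 (0.21 log units; within the scatter). Compound 4 is thus estimated at 2000 nM, with a range from 700 nM to 6000 nM.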

Compound 4, inhibition constant: 1050 nM
Beside the measured number, compound 4's estimate is 1.9-fold (0.28 log units) above it, within the range that was stated.
By their numbers in this assay, from the lowest: compounds 2 and 4 (each within the scatter of the next); then compounds 3 and 1 (each within the scatter of the next).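

In this assay, fluoro on this aromatic carbon cannot be told apart from chloro (a 1.2-fold higher number from compound 2 to compound 4 (0.06 log units; within the scatter)), so the smaller halogen keeps what chloro gave. Fluoro also gives a lower number than either non-halogen group (a 3.1-fold lower number from compound 3 to compound 4 (0.49 log units; beyond the scatter); a 5.6-fold lower number from compound 1 to compound 4 (0.75 log units; beyond the scatter)), so the drop seen with chloro is not unique to that one halogen. Nothing measured here explains these differences.

From the compounds shown here alone, whether bromo or trifluoromethyl on this carbon would match the two halogens remains open. So does whether an amine or a methoxy group would sit closer to methyl and methylsulfanyl.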